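The compounds below may be only part of what the source reports. "The series", "measured", "known", "first", "only" and "open" are said of these compounds alone.

Measured compounds:
- Compound 1 `COc1cc(-c2cc(/C=C/C(C)=O)[nH]n2)cc(OC)c1OC` gives 27300 nM in a functional assay on MDA-MB-231 cells (Homo sapiens) for inhibition, read by MTT assay, with a stated time of 48 h; on this read-out higher numbers stand for weaker inhibition and lower numbers for stronger inhibition.
- Compound 2 `COc1cc(-c2cc(/C=C3\CCc4ccccc4C3=O)[nH]n2)cc(OC)c1OC` gives 9500 nM in this assay.
- Compound 3 `COc1cc2c(cc1OC)C(=O)/C(=C/c1cc(-c3cc(OC)c(OC)c(OC)c3)n[nH]1)C2` gives 2500 nM in this assay.

Compound 1 stands at the highest number of the three, which here means the weakest inhibition. Compound 2 sits at a lower number, and that gap is beyond the usual scatter of repeated measurements; compound 3 sits lower still, the furthest from compound 1. Both of these lower numbers belong to compounds in which the carbonyl is tied into a ring system, whereas compound 1 carries a simple acetyl group on its chain.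

The step from compound 1 to compound 4 `COc1cc(-c2cc(/C=C/C(=O)c3ccccc3)[nH]n2)cc(OC)c1OC` changes exactly that group: phenyl in place of methyl on a carbonyl carbon. Cut one bond further out, the same difference reads acetyl to benzoyl. For the measured compounds named here, no measured pair shows this exact change, so the size of the step can only be expected, not read off. The two compounds whose carbonyl carries more carbon, compound 2 and compound 3, both sit below compound 1, so a move toward stronger inhibition seems more likely than none, though with wide uncertainty. The expected step of a 3.4-fold lower number from compound 1 to compound 4 (0.53 log units; beyond the scatter) is thus a moderate one toward a lower number. Compound 4 is expected to give 8000 nM in this assay, with a range from 2500 nM to 25000 nM.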

Compound 4, half-maximal inhibitory concentration: 2300 nM
Estimate against measurement, compound 4: 3.5-fold (0.54 log units) above; measured number below the stated range.
By their numbers in this assay, from the lowest: compounds 4 and 3 (each within the scatter of the next); then compound 2; then compound 1.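

Replacing methyl with phenyl on a carbonyl carbon gives a 12-fold lower number from compound 1 to compound 4 (1.07 log units; beyond the scatter) in this assay, a large move toward stronger inhibition. The earlier compounds shown here differ from one another in more than one place, so they could not isolate any single group, whereas this pair shows that the group on this carbonyl carbon can by itself shift the number well beyond the scatter. The change adds one six-membered aromatic ring of carbon only and no hydrogen-bond donors or acceptors, but nothing measured here explains why the step is this large.

Still open, from the compounds shown here alone, is whether the aromatic ring is needed, or whether another carbon group on the carbonyl carbon, such as an ethyl, a longer chain or a cyclohexyl, would give a similar step. Going by these compounds, it is also open how the number would respond to a fluorine or a methoxy group on the new phenyl, or to a pyridine ring in its place.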